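Ethyl in Place of Hydroxy: Expectation for Compound 4

A few compounds are considered here, and "the series" means these few. Any claim that something is new, unique, unknown or untested is made for them only; others in the source may bear on it.

Compound 1 `CC(C)c1onc(-c2c(Cl)cccc2Cl)c1COc1ccc(-c2ccc3cc(C(=O)O)cnc3c2)cc1`: 200 nM
Compound 2 `CC(C)c1onc(-c2c(Cl)cccc2Cl)c1COc1ccc(-c2ccc3nc(C(=O)O)cnc3c2)cc1`: 150 nM
Compound 3 `CC(C)c1onc(-c2c(Cl)cccc2Cl)c1COc1ccc(-c2ccc3nc(C(=O)O)cc(O)c3c2)cc1`: 51 nM

In a functional assay for agonist activity at Bile acid receptor (Homo sapiens), read by FRET (a lower number here means that less compound is needed, a higher number that more compound is needed for the effect), compound 3 stands lowest of the three. Its distance from compound 2 and from compound 1 lies beyond the scatter, so compound 3 is the most potent of the measured set. Compound 4 `CCc1cc(C(=O)O)nc2ccc(-c3ccc(OCc4c(-c5c(Cl)cccc5Cl)noc4C(C)C)cc3)cc12` differs from compound 3 in one place: ethyl in place of hydroxy on an aromatic carbon. Among the measured compounds shown here, no measured pair shows this exchange, so the set gives no direct measure of its size or direction. With the hydroxy gone and an ethyl in its place, compound 4 is expected to give 130 nM in this assay, between 40 nM and 450 nM. The expected step of a 2.5-fold higher number from compound 3 to compound 4 (0.41 log units; beyond the scatter) is a moderate rise, probably beyond the scatter, though the range also allows no change.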

Compound 4, half-maximal effective concentration: 75 nM
For compound 4 the middle estimate is 1.7-fold (0.24 log units) above the measured one; measured number inside the range.
By their numbers in this assay, from the lowest: compounds 3, 4, 2 and 1 (each within the scatter of the next, the first and the last beyond it).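

In this assay, ethyl in place of hydroxy on this aromatic carbon, opposite the ring nitrogen, gives a 1.5-fold higher number from compound 3 to compound 4 (0.17 log units; within the scatter). The position therefore tolerates this exchange, and the hydrogen-bond donor and acceptor counted for hydroxy are not required to keep the number within the scatter. Nothing measured here explains this result.

The compounds shown leave open whether an amine, a methoxy group or a longer chain at this carbon would also be tolerated. They also leave open whether a bare hydrogen there would give a similar number.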